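From methoxycarbonyl to ethoxycarbonyl: one small step

A few compounds are considered here, and "the series" means these few. Any claim that something is new, unique, unknown or untested is made for them only; others in the source may bear on it.

Measured in a functional assay on NCI-H460 cells (Homo sapiens); a lower number here means a stronger inhibitor, a higher number a weaker inhibitor:
- compound 1 `COc1cc(NC(C)CCCNC(=O)NOCc2ccccc2)c2ncccc2c1`: 21000 nM
- compound 2 `COC(=O)NCCCC(C)Nc1cc(OC)cc2cccnc12`: > 100000 nM

Compound 2 gives > 100000 nM, which is a limit of the assay and not a number. It stands at the limit of > 100000 nM in this assay, at which 1 of the 2 values shown sits.

The next compound, compound 3 `CCOC(=O)NCCCC(C)Nc1cc(OC)cc2cccnc12`, differs from compound 2 by a single change: methyl in place of hydrogen on a saturated chain carbon bound to an oxygen next to a carbonyl group. Methoxycarbonyl thus becomes ethoxycarbonyl.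

Among the measured compounds shown here, only one measured change bears on this, an at least 4.7-fold higher number from compound 1 to compound 2 (0.67 log units; beyond the scatter), where methoxy took the place of (benzyloxy)amino on a carbonyl carbon. That exchange was much larger than adding one methyl, so a step beyond the scatter is not expected in this assay, and compound 3 should remain weak, perhaps at the same limit. The expected step is a number no higher from compound 2 to compound 3 (the limit leaves the size open). Compound 3 is estimated at 100000 nM, with an expected range of 35000 nM to 200000 nM.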

Compound 3, half-maximal inhibitory concentration: 38000 nM
Estimate against measurement, compound 3: 2.6-fold (0.42 log units) above; the measured number falls inside the stated range.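

At this position, on a saturated chain carbon bound to an oxygen next to a carbonyl group, a single added methyl is enough to bring the compound into the measurable range of this assay, with an at least 2.6-fold lower number from compound 2 to compound 3 (0.42 log units; beyond the scatter). Compound 2 gives > 100000 nM, which is a limit of the assay and not a number. Replacing the (benzyloxy)amino group with ethoxy gives a 1.8-fold higher number from compound 1 to compound 3 (0.26 log units; within the scatter), so the (benzyloxy)amino group is not required for this level of activity, something the methoxy compound could not show.

On these data alone, the true size of the methyl step stays open, since only a limit exists for compound 2. Also open, as far as these compounds go, is whether a longer chain, such as propoxycarbonyl or butoxycarbonyl, would lower the number further or whether it would stay level.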